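A few compounds are considered here, and "the series" means these few. Any claim that something is new, unique, unknown or untested is made for them only; others in the source may bear on it.

Measured compounds in this series:

compound 1 `COc1cc(-c2nn(-c3cccc(NC(=O)Nc4ccc(Cl)c(Cl)c4)c3)cc2-c2ccncc2)ccc1Cl` — > 50000 nM
compound 2 `O=C(Nc1cccc(-n2cc(-c3ccncc3)c(-c3ccc(Cl)c(O)c3)n2)c1)Nc1ccc(Cl)c(Cl)c1` — > 32500 nM

In a functional assay on CAKI-1 cells (Homo sapiens) for inhibition, read by sulforhodamine B assay, with a stated time of 48 h (a lower number here means that less compound is tolerated, a higher number that more compound is tolerated), compound 1 gives > 50000 nM, which is a limit of the assay and not a number; this is the limit of > 50000 nM in this assay, at which 1 of the 2 values shown sits. Compound 2 gives > 32500 nM in this assay, likewise a limit; this is the limit of > 32500 nM in this assay, at which 1 of the 2 values shown sits. Compound 1 therefore stands at a limit, and the other value shown is a limit as well, so neither compound can be placed on a scale against the other. For the measured compounds named here, the one measured step, a step that the two limits leave unreadable from compound 1 to compound 2, gives no readable size because the limit of > 32500 nM in this assay, at which 1 of the 2 values shown sits, and the limit of > 50000 nM in this assay, at which 1 of the 2 values shown sits, close off both of its ends.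

Compound 3 `COc1cc(-c2nn(-c3cccc(NC(=O)Nc4ccc(Cl)c(C(F)(F)F)c4)c3)cc2-c2ccncc2)ccc1Cl` differs from compound 1 by trifluoromethyl in place of chloro on an aromatic carbon, ortho to a chloro group and meta to a large group. Going by the values given here, no measured step touches this change, and the only step available is itself unreadable, so there is nothing from which a direction or size could be drawn. Compound 3 is expected to give 60000 nM in this assay, with a range of 30000 nM to 120000 nM. The expected step, a step that the limit leaves unreadable from compound 1 to compound 3, is thus taken to stay within the scatter, and compound 3 is most likely to return only a limit again.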

Compound 3, concentration lethal to 50% of the cells: > 32500 nM
Compound 3 gave a limit, no number; the forecaster's own chance of this, stated with the estimate: 85%; the middle value does not contradict the limit.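

For the compounds shown here, compound 1 and compound 3 both return only limits of the assay and not numbers, so the change to trifluoromethyl in place of chloro on an aromatic carbon gives no new readable step. The compounds shown leave open how the two groups compare here, and whether any compound in the series gives a number rather than a limit.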